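The source may report more compounds than this note shows. Statements on the series, on what has been measured and on what is new or still open speak of the compounds shown alone.

Measured so far in a functional assay on Jurkat cells (Homo sapiens) for cytotoxicity, read by MTT assay, with a stated time of 72 h; on this read-out higher numbers stand for weaker inhibition and lower numbers for stronger inhibition:
Compound 1 `C=C1C2=C(C(=O)N1OC)[C@H](O)[C@@](C)(O)[C@H](CCCCC)O2`: 10000 nM
Compound 2 `C=C1C2=C(C(=O)N1OC)[C@H](OC(=O)CSc1nc3ccccc3o1)[C@@](C)(O)[C@H](CCCCC)O2`: 2600 nM
Compound 3 `C=C1C2=C(C(=O)N1OC)[C@@H](F)[C@@](C)(O)[C@H](CCCCC)O2`: 15000 nM

On these numbers compound 2 stands lowest, and both other compounds lie beyond the usual scatter from it: compound 1 sits a clear distance above it, and compound 3 further still. Compound 4 `C=C1C2=C(C(=O)N1OC)[C@H](OC(=O)CCl)[C@@](C)(O)[C@H](CCCCC)O2` has not been measured yet. It is built from compound 2 by one change, (chloro in place of (1,3-benzoxazol-2-yl)sulfanyl on a saturated chain carbon bound to a carbonyl carbon). Going by the values given here, no step between two measured compounds matches this change, so there is no direct guide to its size. What the measured compounds do show is that compound 1, which carries no ester at this position, gives 10000 nM, a weaker result than compound 2 with 2600 nM. Compound 4 keeps the ester but carries a far smaller group on it, so the expectation is a number between those two, most likely a small rise that may stay within the scatter. The expected step is a 1.5-fold higher number from compound 2 to compound 4 (0.19 log units; within the scatter). The estimate for compound 4 is therefore 4000 nM, with a range from 1200 nM to 13000 nM.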

Compound 4, half-maximal inhibitory concentration: 9600 nM
Beside the measured number, compound 4's estimate is 2.4-fold (0.38 log units) below it; the measured number falls inside the stated range.
By their numbers in this assay, from the lowest: compound 2; then compounds 4, 1 and 3 (each within the scatter of the next).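

In this assay chloro in place of (1,3-benzoxazol-2-yl)sulfanyl gives a 3.7-fold higher number from compound 2 to compound 4 (0.57 log units; beyond the scatter) and so the lower number of compound 2 does not come from the ester alone. Putting (chloromethyl)carbonyl in place of hydrogen on the oxygen gives a 1.0-fold lower number from compound 1 to compound 4 (0.02 log units; within the scatter) and this step lies within the scatter, so an ester carrying only chloro does not set itself apart from compound 1. Among these compounds, the stronger inhibition goes with the (1,3-benzoxazol-2-yl)sulfanyl group rather than with the ester link itself.

The compounds shown leave open whether a single aromatic ring such as phenylsulfanyl or a simple amine on the same chain carbon would keep the number of compound 2. Nothing measured here explains the difference between the two groups.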